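The compounds below may be only part of what the source reports. "The series", "measured", "known", "first", "only" and "open" are said of these compounds alone.

Measured so far in an ADME assay on WI-38 cells (Homo sapiens) for inhibition, read by CellTiter-Glo, with a stated time of 48 h, tested at 100 uM; a lower number here means less inhibition, a higher number more inhibition at the concentration tested (going by the name of the read-out):
Compound 1 `CCOC(=O)/C=C/NC(=O)[C@H](O)C(C)(C)CO` gives 36% in this assay.
Compound 2 `CC(C)(CO)[C@H](O)C(=O)N/C=C/C(=O)OCc1ccccc1` gives 19% in this assay.
Compound 3 `COC(=O)/C=C/NC(=O)[C@@H](O)C(C)(C)CO` gives -18% in this assay.

Compound 1 stands highest of the three numbers. The nearest is compound 2, lower by a margin beyond the scatter; the furthest is compound 3, lower by a margin well beyond the scatter. Among the measured compounds shown here, the one step between measured compounds that differ in a single place is a number 37 percentage points lower from compound 2 to compound 3 (beyond the scatter), where hydrogen replaces phenyl on a saturated chain carbon bound to an oxygen next to a carbonyl group; it is a large step, but it swaps atoms.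

Compound 4 `CCOC(=O)/C=C\NC(=O)[C@H](O)C(C)(C)CO` is not yet measured. Its relation to compound 1 is the two compounds have the same atoms and bonds and differ only in configuration as drawn: 1 of 2 stereo elements differ; a double bond is drawn E in compound 1 and Z in compound 4. For the measured compounds named here, no measured step changes only drawn configuration, so the size of the known step gives no direct guide here. With nothing in the measured pairs to argue for a shift either way, the expected step is a number 6 percentage points lower from compound 1 to compound 4 (within the scatter), which is within the scatter. The estimate for compound 4 in this assay is 30%, with a range from 5% to 55%, the width reflecting that no comparable change has been measured.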

Compound 4, a percentage reported as inhibition, at one concentration (the size of the read-out at that concentration, not a potency): 1%
Compound 4: middle estimate off by 29 percentage points, on the high side; measured number below the stated range.
By their numbers in this assay, from the lowest: compound 3; then compound 4; then compound 2; then compound 1.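

The drawn geometry of the double bond is enough on its own to move the read-out in this assay, with a number 35 percentage points lower from compound 1 to compound 4 (beyond the scatter). The earlier single-place step, a number 37 percentage points lower from compound 2 to compound 3 (beyond the scatter), swapped atoms, so it said nothing about configuration; here nothing leaves and nothing enters, and the E form of compound 1 and the Z form of compound 4 still read apart by a margin beyond the scatter. The step can therefore be assigned to the double bond alone, and not to any change of substituent, though it rests on this one pair: the fact that compounds 1 and 4 differ only in the configuration as drawn

Still open, from the compounds shown here alone, is whether the same change from E to Z carries over to the other esters, since compound 2 and compound 3 appear here only with the double bond drawn E, and whether its direction and size hold at all outside the ethyl ester. Also open, going by these compounds, is how a carboxylic acid or an amide in place of the ester would read in this assay, and whether the configuration of the double bond would matter to the same extent with either group there.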